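Changing the Aryl Group on a Shared Core

The source may hold more compounds than are shown below. What is called first, only, known or untested is meant among the compounds shown, and "the series" means these compounds.

In an ADME assay on HepG2 cells (Homo sapiens) for cytotoxicity, read by fluorescence and resazurin assay, with a stated time of 24 h (a higher number here means that more compound is tolerated, a lower number that less compound is tolerated), compound 1 (`O=S1(=O)C=C(Sc2nnc(-c3ccccc3Cl)o2)c2ccccc21`) gives 25000 nM and compound 2 (`COc1cccc(-c2nnc(SC3=CS(=O)(=O)c4ccccc43)o2)c1`) gives 20000 nM as its half-maximal cytotoxic concentration. Among the measured compounds shown here, compound 2 therefore stands within the scatter of compound 1, the only other measured compound, and the two cannot be ranked.

Compound 3 (`Cc1ccc(-c2nnc(SC3=CS(=O)(=O)c4ccccc43)o2)cc1`) keeps the shared core and carries 4-methylphenyl in place of 3-methoxyphenyl on an aromatic carbon. The counted difference is 4-methylphenyl in place of 3-methoxyphenyl on an aromatic carbon and nothing else changes.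

For the measured compounds named here, one measured step bears on this change, since compounds 1 and 2 differ at the same place: a 1.3-fold lower number from compound 1 to compound 2 (0.10 log units; within the scatter) is all the evidence available. That step stayed within the scatter, so no step beyond the scatter is expected here. The basis is thin, as it rests on two compounds and neither carries 4-methylphenyl.

The expected result is no change at the digits printed from compound 2 to compound 3 (within the scatter) in this assay on this reasoning. For compound 3 the estimate is 20000 nM with an expected range of 9000 nM to 42000 nM when it is measured.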

Compound 3, half-maximal cytotoxic concentration: 31000 nM
Beside the measured number, compound 3's estimate is 1.6-fold (0.19 log units) below it; low and high end bracket the measured number.
By their numbers in this assay, from the lowest: compounds 2, 1 and 3 (each within the scatter of the next).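

In this assay, 4-methylphenyl in place of 3-methoxyphenyl on this aromatic carbon gives a 1.6-fold higher number from compound 2 to compound 3 (0.19 log units; within the scatter), and 4-methylphenyl in place of 2-chlorophenyl gives a 1.2-fold higher number from compound 1 to compound 3 (0.09 log units; within the scatter). The position has now carried three different substituted phenyl groups, and every step among them stays within the scatter, even though the entering 4-methylphenyl has no oxygen and no hydrogen-bond acceptors, so the three compounds cannot be ranked in this read-out. No measurement is available that would explain these numbers.

All three groups are substituted six-membered aromatic rings of carbon only, so the compounds leave open whether something of another kind on this carbon, such as an amine, a carboxylic acid or a longer alkyl chain, would give a step beyond the scatter. Among the compounds shown here, they also leave open what the substituent's place on the phenyl ring contributes, as 2-chlorophenyl, 3-methoxyphenyl and 4-methylphenyl differ in both the substituent and its ring number, and no pair here changes only one of the two.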